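Series notes: aryl replacement on the carbonyl carbon

The source may report more compounds than this note shows. Statements on the series, on what has been measured and on what is new or still open speak of the compounds shown alone.

Going by the values given here, compound 2 `COc1ccc(C(=O)/C=C/c2cc(-c3cc(OC)c(OC)c(OC)c3)n[nH]2)cc1` stands highest of the two numbers measured so far: in a functional assay on MDA-MB-231 cells (Homo sapiens) for cytotoxicity, read by sulforhodamine B assay, with a stated time of 48 h, tested at 1 uM (on this read-out lower numbers stand for a stronger effect and higher numbers for a weaker effect at the one concentration tested), compound 2 gives 81%. Among the compounds with values here, compound 1 `COc1cc(-c2cc(/C=C/C(=O)c3ccc(N)cc3)[nH]n2)cc(OC)c1OC` gives 70% in this assay, and the only measured step, a number 11 percentage points higher from compound 1 to compound 2 (beyond the scatter), concerns methoxy in place of amino on an aromatic carbon. Compound 3 `COc1cc(-c2cc(/C=C/C(=O)c3ccc(F)c(F)c3)[nH]n2)cc(OC)c1OC` differs from compound 2 as follows: 3,4-difluorophenyl in place of 4-methoxyphenyl on a carbonyl carbon. Within the data shown here, no measured step touches this change; the one step known runs elsewhere and was modest. For compound 3 the expected step is therefore a number 3 percentage points lower from compound 2 to compound 3 (within the scatter), nothing beyond the scatter. Compound 3 is estimated at 78% in this assay, range 55% to 95%.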

Compound 3, a percentage reported as activity, at one concentration (the size of the read-out at that concentration, not a potency): 74%
The estimate for compound 3 lay 4 percentage points above the measured number; measured number inside the range.
By their numbers in this assay, from the lowest: compounds 1, 3 and 2 (each within the scatter of the next, the first and the last beyond it).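

On a carbonyl carbon, 3,4-difluorophenyl in place of 4-methoxyphenyl gives a number 7 percentage points lower from compound 2 to compound 3 (within the scatter) in this assay, while 3,4-difluorophenyl in place of 4-aminophenyl gives a number 4 percentage points higher from compound 1 to compound 3 (within the scatter) at the same position. Going by these compounds alone, this is the first change of the whole aryl group here, and neither step separates compound 3 from its neighbour, although compound 1 and compound 2 stand apart. Nothing available explains these numbers.

Open, going by these compounds, is how a carboxylic acid or a nitrile on the phenyl ring would read at this position. Also open is whether a single concentration hides differences among these compounds that a full concentration series would show.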